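This account rests on a few compounds, and the source may have more. Where it says the series, first, only, none or still open, it means among the compounds named here.

In an ADME assay on CCRF-CEM cells (Homo sapiens) for antiproliferative activity, with a stated time of 48 h (on this read-out lower numbers stand for stronger inhibition and higher numbers for weaker inhibition), compound 1 `C=C(Br)C(=O)Nc1ccc(/C=C/C(=O)c2ccc(Br)cc2)cc1` gives 990 nM, while compound 2 `C=C(Br)C(=O)Nc1ccc(/C=C/C(=O)c2ccc(I)cc2)cc1` gives 4000 nM, the higher and thus weaker of the two numbers. Compound 3 `C=C(Br)C(=O)Nc1ccc(/C=C/C(=O)c2cccs2)cc1` departs from compound 2 in one place: thiophen-2-yl in place of 4-iodophenyl on a carbonyl carbon. In words, thiophen-2-yl stands in place of 4-iodophenyl on a carbonyl carbon. For the measured compounds named here, no measured compound carries thiophen-2-yl, so the evidence is thin. Going by the values given here, the only step that bears on the change is a 4.0-fold higher number from compound 1 to compound 2 (0.61 log units; beyond the scatter), a modest step beyond the scatter, with iodo in place of bromo on an aromatic carbon. Iodo leaves again in the present change, which points weakly to a modest move towards stronger inhibition, of about that size or less. The expected step is a 2.2-fold lower number from compound 2 to compound 3 (0.35 log units; beyond the scatter). For compound 3 the estimated value is 1800 nM, with an expected range from 500 nM to 6000 nM.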

Compound 3, half-maximal inhibitory concentration: 730 nM
Estimate against measurement, compound 3: 2.5-fold (0.39 log units) above; low and high end bracket the measured number.
By their numbers in this assay, from the lowest: compounds 3 and 1 (each within the scatter of the next); then compound 2.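

In this assay, thiophen-2-yl in place of 4-iodophenyl on a carbonyl carbon gives a 5.5-fold lower number from compound 2 to compound 3 (0.74 log units; beyond the scatter), so this position does not depend on a six-membered aromatic ring of carbon only to give a number well clear of that of compound 2. Thiophen-2-yl in place of 4-bromophenyl gives a 1.4-fold lower number from compound 1 to compound 3 (0.13 log units; within the scatter), which leaves compound 3 and compound 1 indistinguishable here and sets compound 2 alone apart among the three. Nothing measured explains these steps.

The compounds shown leave open whether plain phenyl, furan-2-yl or a pyridine ring on this carbonyl carbon would group with compound 1 and compound 3 or with compound 2. They also leave open how an amine or a methoxy group on the phenyl ring, in place of the halogen, would compare.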